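Adding a Second Bromo to Compound 3

This account rests on a few compounds, and the source may have more. Where it says the series, first, only, none or still open, it means among the compounds named here.

Compound 1 `O=Cc1cn(Cc2ccc(Br)c(Br)c2)c2ccccc12` gives 63 nM
Compound 2 `OCc1cn(Cc2cccc(Br)c2)c2ccccc12` gives 28 nM
Compound 3 `OCc1cn(Cc2ccc(Br)cc2)c2ccccc12` gives 31 nM

In a functional assay on NCI-H460 cells (Homo sapiens) for cytotoxicity, read by sulforhodamine B assay, with a stated time of 3 days (a higher number here means a weaker inhibitor, a lower number a stronger inhibitor), compound 3 (31 nM) lies within the scatter of compound 2 (28 nM). Compound 1 (63 nM) lies beyond the scatter of compound 3, which has the lower number. Compound 4 `OCc1cn(Cc2ccc(Br)c(Br)c2)c2ccccc12` arises from compound 3 by one change: bromo in place of hydrogen on an aromatic carbon, ortho to a bromo group and meta to a large group (bromo in place of hydrogen on an aromatic carbon). Among the measured compounds shown here, no measured pair isolates this change, and compound 1, which carries both bromo groups, also differs from compound 4 elsewhere. In this assay no step beyond the scatter is expected, in either direction. The estimated change is small (a 1.0-fold lower number from compound 3 to compound 4 (0.01 log units; within the scatter)). For compound 4 the expected value is 30 nM, with an estimated range from 12 nM to 75 nM.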

Compound 4, half-maximal inhibitory concentration: 50 nM
Compound 4: middle estimate off by 1.7-fold (0.22 log units), on the low side; the measured number falls inside the stated range.
By their numbers in this assay, from the lowest: compounds 2, 3, 4 and 1 (each within the scatter of the next, the first and the last beyond it).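

In this assay the bromo added on the aromatic carbon ortho to a bromo group gives a 1.6-fold higher number from compound 3 to compound 4 (0.21 log units; within the scatter) and, read from the other single-bromo compound, a 1.8-fold higher number from compound 2 to compound 4 (0.25 log units; within the scatter) so the second bromo shifts nothing beyond the scatter from either starting point. With both bromo groups in place, hydroxymethyl in place of formyl gives a 1.3-fold lower number from compound 1 to compound 4 (0.10 log units; within the scatter) and this change also stays within the scatter. No measurement here accounts for these steps.

The compounds shown leave open whether a methoxy group or an amine in place of this second bromo would give a step beyond the scatter. They also leave open what a carboxylic acid in place of the hydroxymethyl would do.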